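A few compounds are considered here, and "the series" means these few. Any claim that something is new, unique, unknown or untested is made for them only; others in the source may bear on it.

Compound 1 `Cc1ccc(N2CCN(CCNC(=O)c3ccco3)CC2)cc1` carries a furan-2-yl group on the carbonyl carbon, and in a functional assay for antagonist activity at Adrenergic receptor alpha-1 (Rattus norvegicus) (on this read-out higher numbers stand for weaker binding and lower numbers for tighter binding), compound 1 gives 339 nM, the highest of the three numbers in hand. Compound 2 `Cc1ccc(N2CCN(CCNC(=O)c3ccncc3)CC2)cc1` bears pyridin-4-yl in that place, and in this assay compound 2 gives 316 nM, a change of a 1.1-fold lower number from compound 1 to compound 2 (0.03 log units; within the scatter). Compound 3 `Cc1ccc(N2CCN(CCNC(=O)c3cc4ccccc4o3)CC2)cc1` bears 1-benzofuran-2-yl there; in this assay compound 3 gives 120 nM, which is a 2.8-fold lower number from compound 1 to compound 3 (0.45 log units; beyond the scatter) and a 2.6-fold lower number from compound 2 to compound 3 (0.42 log units; beyond the scatter).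

Compound 4 `Cc1ccc(N2CCN(CCNC(=O)c3ccco3)CC2)c(C)c1` differs from compound 1 in another part of the molecule: methyl in place of hydrogen on an aromatic carbon, so that the 4-methylphenyl of compound 1 becomes 2,4-dimethylphenyl. None of the three measured steps touches this part of the shared core; all of them exchange the group on the carbonyl carbon, and even the largest among them was only modest. Among the compounds with values here, there is therefore no measured step that bears directly on the change from compound 1 to compound 4, and the most defensible expectation is a step in this assay of no more than the usual scatter, in either direction. The estimated step is a 1.1-fold lower number from compound 1 to compound 4 (0.05 log units; within the scatter). For compound 4 the expected value in this assay is 300 nM, with a range from 90 nM to 1000 nM.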

Compound 4, dissociation constant: 19.1 nM
Compound 4: middle estimate off by 16-fold (1.20 log units), on the high side; the measured number lies below the stated range.
By their numbers in this assay, from the lowest: compound 4; then compound 3; then compounds 2 and 1 (each within the scatter of the next).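

In this assay, within the data shown here, the change from 4-methylphenyl to 2,4-dimethylphenyl (an 18-fold lower number from compound 1 to compound 4 (1.25 log units; beyond the scatter)) shows that this part of the molecule responds far more strongly than the earlier compounds could reveal. A single methyl, one heavy atom with no ring, no hydrogen-bond donors or acceptors and no net charge, placed on an aromatic carbon ortho to a large group, moves the number much further than the largest exchange on the carbonyl carbon (a 2.8-fold lower number from compound 1 to compound 3 (0.45 log units; beyond the scatter)). Nothing measured here accounts for the size of this step.

The compounds shown leave open whether methyl is special at this place or whether a methoxy group, a chlorine atom or an amine there would move the number as far, and whether the methyl already present in 4-methylphenyl contributes to the step. They also leave open whether the same methyl gives a step of similar size when 1-benzofuran-2-yl or pyridin-4-yl, rather than furan-2-yl, sits on the carbonyl carbon.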